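The source may report more compounds than this note shows. Statements on the series, on what has been measured and on what is new or still open speak of the compounds shown alone.

Measured so far:
- compound 1, `COc1c(Cl)ccc2c1CCC2c1ncc[nH]1`: 24% in a functional assay on CHO cells for agonist activity at Alpha-1A adrenergic receptor (Homo sapiens), read by FLIPR and calcium flux; on this read-out lower numbers stand for smaller maximal responses and higher numbers for larger maximal responses
- compound 2, `CCS(=O)(=O)Nc1cccc2c1CCC2c1ncc[nH]1`: 86%

Among the compounds with values here, compound 2 stands highest of the two numbers in this assay; the only neighbour is compound 1, whose value lies below it by a gap beyond the usual scatter of this assay. Within the data shown here, compound 1 and compound 2 differ in several places at once, so their two values show only that the series spans a wide range of maximal response and give no single step to lean on.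

Compound 3, `Cn1nccc1-c1cccc2c1CCC2c1ncc[nH]1`, is not yet measured. It differs from compound 2 in one place: 1-methyl-1H-pyrazol-5-yl in place of (ethylsulfonyl)amino on an aromatic carbon.

Among the measured compounds shown here, no step between measured compounds describes this change. With one hydrogen-bond donor leaving and an aromatic ring entering, and compound 2 already at 86%, a downward step in this assay is expected, of moderate size, though a result within the scatter cannot be excluded. For compound 3 the estimated value is 55%, in the range 20% to 90%, which is expected to mean a step of a number 31 percentage points lower from compound 2 to compound 3 (beyond the scatter).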

Compound 3, largest response reached (Emax), in percent of the reference or control that the assay uses: 58%
Compound 3: middle estimate off by 3 percentage points, on the low side; the measured number falls inside the stated range.
By their numbers in this assay, from the lowest: compound 1; then compound 3; then compound 2.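

Within the data shown here, on the aromatic carbon ortho to a fused ring, 1-methyl-1H-pyrazol-5-yl in place of (ethylsulfonyl)amino gives a number 28 percentage points lower from compound 2 to compound 3 (beyond the scatter) in this assay, the first single-place step. The position thus accepts a group without a hydrogen-bond donor and with a five-membered aromatic ring, and compound 3 retains a clear maximal response at 58%. This one pair cannot separate the loss of the donor from the gain of the ring, and no supporting data bear on the cause of the step.

Open, from the compounds shown here alone, is how a plain amine, a methylsulfonylamino group or a pyrazolyl ring without the methyl would read at this carbon. A carboxamide or a carboxylic acid here would test whether a donor matters for the size of the response.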